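A few compounds are considered here, and "the series" means these few. Any claim that something is new, unique, unknown or untested is made for them only; others in the source may bear on it.

Measured so far in an assay on BaF3 cells for inhibition of thrombopoietin receptor (Homo sapiens); on this read-out lower numbers stand for an effect already at smaller amounts and higher numbers for an effect only at larger amounts of compound:
compound 1 `CC1=NN(c2ccc3c(c2)CCC3)C(=O)/C1=C(/C)NNC(=O)N1CCc2cc(C(=O)O)ccc21` — 46 nM
compound 2 `CC1=NN(c2ccc3c(c2)CCC3)C(=O)/C1=C(/C)NNC(=S)N1CCCc2cc(C(=O)O)ccc21` — 35 nM
compound 3 `CC1=NN(c2ccc(C)c(C)c2)C(=O)/C1=C(/C)NNC(=S)N1CCc2cc(C(=O)N3CCOCC3)ccc21` — 31 nM

Compound 3 sits close to both others in this assay: the gap to compound 2 is small, and the gap to compound 1 is likewise within the scatter, so the three numbers cannot be told apart. Compound 4 `CC1=NN(c2ccc(C)c(C)c2)C(=O)/C1=C(/C)NNC(=S)N1CCc2cc(C(=O)O)ccc21` is not yet measured. It differs from compound 3 by hydroxy in place of morpholin-4-yl on a carbonyl carbon — hydroxy in place of morpholin-4-yl on a carbonyl carbon. Compound 1 at 46 nM and compound 2 at 35 nM already carry a carboxy and give numbers close to compound 3, so no step beyond the scatter is anticipated in either direction. The expected step is a 1.1-fold higher number from compound 3 to compound 4 (0.05 log units; within the scatter). For compound 4 the estimate is 35 nM, with a range of 15 nM to 80 nM.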

Compound 4, half-maximal effective concentration: 6 nM
The estimate for compound 4 lay 5.8-fold (0.77 log units) above the measured number; measured number outside the range, below it.
By their numbers in this assay, from the lowest: compound 4; then compounds 3, 2 and 1 (each within the scatter of the next).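

In this assay, going from (morpholin-4-yl)carbonyl to carboxy gives a 5.2-fold lower number from compound 3 to compound 4 (0.71 log units; beyond the scatter), so the number responds to what sits on this carbonyl carbon. Within the data shown here, compound 1 and compound 2 also carry a carboxy but differ from compound 4 in more than one place, so only this pair isolates the change. Nothing available explains the step.

Open, going by these compounds, is whether a methyl ester or a dimethylamide on the same carbonyl carbon reads like compound 3 or compound 4. Also open, on these data alone, is whether the morpholin-4-yl to hydroxy change gives a similar step on the core of compound 1 or compound 2.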